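Swapping one aromatic group on the shared core

This account rests on a few compounds, and the source may have more. Where it says the series, first, only, none or still open, it means among the compounds named here.

- Compound 1 `O=C1C=CC2(C=C1)OCC(=O)N2c1nc(-c2ccc3ncccc3c2)nn1-c1ccccc1`: 50 nM
- Compound 2 `O=C1C=CC2(C=C1)OCC(=O)N2c1nc(-c2ccc3c(c2)OCCO3)nn1-c1ccccc1`: 100 nM
- Compound 3 `Cc1ccccc1-n1nc(-c2cccc3ccccc23)nc1N1C(=O)COC12C=CC(=O)C=C2`: 120 nM

In a functional assay on MDA-MB-231 cells (Homo sapiens) for antiproliferative activity, with a stated time of 5 days (on this read-out lower numbers stand for stronger inhibition and higher numbers for weaker inhibition), compound 2 gives 100 nM, which lies within the usual scatter of both compound 3 and compound 1. Compound 4 `O=C1C=CC2(C=C1)OCC(=O)N2c1nc(-c2ccc3ccccc3c2Br)nn1-c1ccccc1` carries 1-bromonaphthalen-2-yl in place of 2,3-dihydro-1,4-benzodioxin-6-yl on an aromatic carbon. Among the compounds with values here, one measured step bears on this place: a 2.0-fold higher number from compound 1 to compound 2 (0.30 log units; within the scatter), where quinolin-6-yl gave way to 2,3-dihydro-1,4-benzodioxin-6-yl. Within the data shown here, no measured compound carries bromine, so this evidence is thin. No change beyond the scatter is expected, and the estimated step is a 1.2-fold higher number from compound 2 to compound 4 (0.08 log units; within the scatter). For compound 4 the estimated value is 120 nM, with an expected range from 40 nM to 350 nM.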

Compound 4, half-maximal inhibitory concentration: 50 nM
Beside the measured number, compound 4's estimate is 2.4-fold (0.38 log units) above it; the measured number falls inside the stated range.
By their numbers in this assay, from the lowest: compounds 1, 4, 2 and 3 (each within the scatter of the next, the first and the last beyond it).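

Three different groups now sit at this place on the shared core without a change beyond the scatter in this assay: the record shows a 2.0-fold lower number from compound 2 to compound 4 (0.30 log units; within the scatter), and no change at the digits printed from compound 1 to compound 4 (within the scatter). The entering 1-bromonaphthalen-2-yl has no hydrogen-bond acceptors and carries bromine, so neither the acceptors of 2,3-dihydro-1,4-benzodioxin-6-yl nor a bromine-free group is required for numbers in this range. No supporting data explain why these groups read alike. Going by these compounds, whether a non-aromatic group here, such as an amine or a carboxylic acid, would give similar numbers remains open.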